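Benzofuran amidoximes: a phenoxymethyl group replaces a piperidine amide

A few compounds are considered here, and "the series" means these few. Any claim that something is new, unique, unknown or untested is made for them only; others in the source may bear on it.

Compound 1 `O/N=C(/Nc1cccc(F)c1)c1ccc2occc2c1` gives, in an assay on isolated protein for inhibition of Indoleamine 2,3-dioxygenase 1 (Homo sapiens), read by spectrophotometry (a higher number here means a weaker inhibitor, a lower number a stronger inhibitor), a value of 32700 nM. Compound 2 `CC1CCN(C(=O)c2cccc(N/C(=N/O)c3ccc4occc4c3)c2)CC1` reaches only the limit of the assay, > 30000 nM, and no number is known for it. The step that the limit leaves unreadable from compound 1 to compound 2 therefore cannot be sized, which follows from the limit of > 30000 nM in this assay, at which 1 of the 2 values shown sits. Compound 3 `O/N=C(/Nc1cccc(COc2ccccc2)c1)c1ccc2occc2c1` is built from compound 2 by phenoxymethyl in place of (4-methylpiperidin-1-yl)carbonyl on an aromatic carbon. Among the compounds with values here, the only measured step, from compound 1 to compound 2, bears on a change at the same carbon but remains unreadable, so no direction beyond the scatter can be drawn from it for this new exchange. Both measured compounds sit at the weak end of the assay. Compound 3 is expected to stay near that end, with an estimated value of 30000 nM, between 8000 nM and 100000 nM. The estimated step from compound 2 to compound 3 is a number no higher from compound 2 to compound 3 (the limit leaves the size open).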

Compound 3, half-maximal inhibitory concentration: > 30000 nM
Compound 3 gave a limit, no number; the forecaster's own chance of this, stated with the estimate: 50%; the middle value sits exactly at the limit.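

Compound 2 and compound 3 both give only a limit in this assay, so the steps from compound 2 to compound 3 and from compound 1 to compound 3 cannot be read: the limit of > 30000 nM in this assay, at which 2 of the 3 values shown sit.

The compounds shown leave open how phenoxymethyl, (4-methylpiperidin-1-yl)carbonyl and fluoro compare on this aromatic carbon.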